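From 2-fluorophenyl to 3-aminophenyl at one aromatic carbon

The source may report more compounds than this note shows. Statements on the series, on what has been measured and on what is new or still open speak of the compounds shown alone.

In a functional assay on MCF7 cells (Homo sapiens) for cytotoxicity, read by MTT assay, with a stated time of 96 h (a higher number here means a weaker inhibitor, a lower number a stronger inhibitor), compound 2 `COc1cc(C(=O)c2cn(-c3ccc(F)cc3)cc2-c2ccccc2F)cc(OC)c1OC` gives 39 nM, within the scatter of compound 1 `COc1cc(C(=O)c2cn(-c3ccc(C)cc3)cc2-c2cccc(N)c2)cc(OC)c1OC` at 53 nM. Compound 3 `COc1cc(C(=O)c2cn(-c3ccc(F)cc3)cc2-c2cccc(N)c2)cc(OC)c1OC` differs from compound 2 by having 3-aminophenyl in place of 2-fluorophenyl on an aromatic carbon. Among the compounds with values here, no measured pair isolates this change. Compound 1 also carries 3-aminophenyl and gives 53 nM, so no change beyond the scatter is expected in this assay. The expected step of a 1.1-fold lower number from compound 2 to compound 3 (0.05 log units; within the scatter) is correspondingly small. Compound 3 is estimated at 35 nM, with an expected range from 12 nM to 100 nM.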

Compound 3, half-maximal inhibitory concentration: 53 nM
Compound 3: middle estimate off by 1.5-fold (0.18 log units), on the low side; the measured number falls inside the stated range.
By their numbers in this assay, from the lowest: compounds 2, 1 and 3 (each within the scatter of the next).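

With 3-aminophenyl in place of 2-fluorophenyl, this assay shows a 1.4-fold higher number from compound 2 to compound 3 (0.13 log units; within the scatter) on this aromatic carbon of the five-membered ring, so in this pair the position holds either group with no change beyond the scatter. Fluoro in place of methyl on an aromatic carbon gives no change at the digits printed from compound 1 to compound 3 (within the scatter) with 3-aminophenyl kept in both compounds, so that group's number is now seen in a matched pair. Going by these compounds, whether a carboxylic acid or a longer alkyl chain on this aromatic carbon would keep the number within the scatter stays open. Nothing available bears on the reason for these results.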